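The compounds below may be only part of what the source reports. "The series", "measured", "known", "first", "only" and "open" are said of these compounds alone.

Working notes on the series, read in a functional assay on MCF7 cells (Homo sapiens) for cytotoxicity, read by sulforhodamine B assay; a higher number here means a weaker inhibitor of growth, a lower number a stronger inhibitor of growth. Compound 1 `CC1=CC[C@@H]([C@@](C)(O)CCCC(C)(C)NC(=S)N/N=C\c2ccc(C)cc2)CC1` gives 7230 nM, compound 2 `CC1=CC[C@@H]([C@@](C)(O)CCCC(C)(C)NC(=S)N/N=C\c2ccc(O)cc2)CC1` gives 6230 nM, and compound 3 `CC1=CC[C@@H]([C@@](C)(O)CCCC(C)(C)NC(=S)N/N=C\c2ccc(N(C)C)cc2)CC1` gives 14000 nM. Compound 3 holds the highest of these numbers, with a 1.9-fold higher number from compound 1 to compound 3 (0.29 log units; within the scatter) and a 2.2-fold higher number from compound 2 to compound 3 (0.35 log units; beyond the scatter). Compound 4 `CC1=CC[C@@H]([C@@](C)(O)CCCC(C)(C)NC(=S)N/N=C\c2cccc([N+](=O)[O-])c2)CC1` carries 3-nitrophenyl in place of 4-(dimethylamino)phenyl on a carbon with a double bond to nitrogen, with 3-nitrophenyl in place of 4-(dimethylamino)phenyl on a carbon with a double bond to nitrogen. Going by the values given here, no measured step brings in this group. The closest guides are those two steps and a 1.2-fold lower number from compound 1 to compound 2 (0.06 log units; within the scatter), all small, so a large change is not expected. The expected step is a 1.8-fold lower number from compound 3 to compound 4 (0.24 log units; within the scatter), with no clear move beyond the scatter. The estimate for compound 4 is 8000 nM, with an expected range of 3500 nM to 18000 nM.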

Compound 4, concentration for 50% growth inhibition: 6720 nM
Compound 4: middle estimate off by 1.2-fold (0.08 log units), on the high side; measured number inside the range.
By their numbers in this assay, from the lowest: compounds 2, 4, 1 and 3 (each within the scatter of the next, the first and the last beyond it).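

In this assay the change from 4-(dimethylamino)phenyl to 3-nitrophenyl on this carbon gives a 2.1-fold lower number from compound 3 to compound 4 (0.32 log units; beyond the scatter) and so moves the number by a modest step. The same group gives a 1.1-fold higher number from compound 2 to compound 4 (0.03 log units; within the scatter) and a 1.1-fold lower number from compound 1 to compound 4 (0.03 log units; within the scatter) so that 3-nitrophenyl cannot be told apart from 4-hydroxyphenyl or 4-methylphenyl at this place, and among these four groups only 4-(dimethylamino)phenyl has any step beyond the scatter, to compound 2 and compound 4 but not to compound 1. No measurement available here accounts for these steps. On these data alone, whether 4-nitrophenyl would match 3-nitrophenyl remains open, as does the effect of a carboxylic acid or a primary amine on the phenyl ring.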